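Compound 3 and its stereochemical counterpart, compound 4

This account rests on a few compounds, and the source may have more. Where it says the series, first, only, none or still open, it means among the compounds named here.

In an ADME assay on a cell-free system (plasma, Rattus norvegicus) for protein binding, compound 1 `COc1ccc(F)cc1-c1ccnc2[nH]c(C3=CCC(C(=O)O)CC3)cc12` gives 99.6%, compound 2 `COc1ccc(F)cc1-c1ccnc2[nH]c(C3=CCC(N[C@@H](C(=O)O)C(C)C)CC3)cc12` gives 94.3% and compound 3 `COc1ccc(F)cc1-c1c(F)cnc2[nH]c(C3=CCN([C@H]4CC[C@@H](C(=O)O)CC4)CC3)cc12` gives 90.1%. The values of compound 3 and compound 2 lie within the scatter of each other, and compound 3 has a much larger unbound fraction than compound 1, a gap well beyond the scatter.

The next compound to be examined is compound 4 `COc1ccc(F)cc1-c1c(F)cnc2[nH]c(C3=CCN([C@H]4CC[C@H](C(=O)O)CC4)CC3)cc12`. Its relation to compound 3 is this: the two compounds have the same atoms and bonds and differ only in configuration as drawn: 2 of 2 stereo elements differ (all stereocentres are inverted: mirror images); a stereocentre at a saturated ring carbon is drawn s in compound 3 and r in compound 4; a stereocentre at a saturated ring carbon is drawn s in compound 3 and r in compound 4. Nothing leaves and nothing enters. Only the two stereocentres at saturated ring carbons differ, each drawn s in compound 3 and r in compound 4.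

Among the compounds with values here, the one measured step, a 14-fold higher unbound fraction from compound 1 to compound 2 (1.15 log units; beyond the scatter), is large, but it came with (1-carboxy-2-methylpropyl)amino in place of carboxy on a saturated ring carbon. It exchanges groups and so gives no guide to a change of configuration alone. Within the data shown here, no measured pair tests such a change, which leaves the expectation resting on compound 3 at 90.1%. In this assay no shift beyond the scatter is therefore expected. The estimated change is a 1.0-fold higher unbound fraction from compound 3 to compound 4 (0.00 log units; within the scatter). Compound 4 is expected at 90%, with an estimated range of 82% to 95.5%.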

Compound 4, plasma protein binding: 89.4%
Compound 4: middle estimate off by 1.1-fold (0.03 log units) (unbound fraction), on the low side; the measured number falls inside the stated range.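

In this assay, inverting both stereocentres at saturated ring carbons gave a 1.1-fold higher unbound fraction from compound 3 to compound 4 (0.03 log units; within the scatter), so at this part of the molecule the plasma protein binding read-out does not separate the two drawn configurations. Within the data shown here, the earlier compounds could not show this: their one step, a 14-fold higher unbound fraction from compound 1 to compound 2 (1.15 log units; beyond the scatter), exchanged groups and left the role of configuration untested, whereas this pair gives a direct reading of a change in configuration with the substituents held constant. The reading can be assigned to configuration alone, and not to any exchange of groups, because of one structural fact: the fact that compounds 3 and 4 differ only in the configuration as drawn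

The compounds shown leave open whether configuration would remain equally without effect if the carboxylic acid on the saturated ring were replaced by a primary amide or a tetrazole, since every compound here carries a carboxylic acid. They also do not tell what inverting only one of the two stereocentres would give, or whether this result extends to any other read-out.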